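The compounds below may be only part of what the source reports. "The series", "measured", "known", "first", "only" and "open" are said of these compounds alone.

Compound 1 `CCCC[C@H]1CN(c2cccc(C)c2C)C(=O)CN1Cc1cncn1Cc1ccc(C#N)cc1` and compound 3 `Cc1cccc(N2CCN(Cc3cncn3Cc3ccc(C#N)cc3)CC2=O)c1C` share one core. In an in vivo ADME assay on the whole organism (plasma) for pharmacokinetics, with Canis familiaris (Canis lupus familiaris) as the target, at a dose of 1 mg/kg by the oral route (a lower number here means less compound in the circulation, a higher number more compound in the circulation at the dose given), compound 1 gives 140 nM, and compound 3 gives 1060 nM. The change between them is hydrogen in place of butyl on a saturated ring carbon, and it brought a 7.6-fold higher number from compound 1 to compound 3 (0.88 log units; beyond the scatter). Compound 2 `CCCC[C@H]1CN(c2cccc(C)c2C)C(=O)C(=O)N1Cc1cncn1Cc1ccc(C#N)cc1` is built on a second core; how the two cores differ is not broken down here. In this assay compound 2 gives 1950 nM. Compound 4 `Cc1cccc(N2CCN(Cc3cncn3Cc3ccc(C#N)cc3)C(=O)C2=O)c1C` stands to compound 2 as compound 3 stands to compound 1, through the same change, (hydrogen in place of butyl on a saturated ring carbon). For compound 4 the step is expected to be a 3.3-fold higher number from compound 2 to compound 4 (0.52 log units; beyond the scatter), more modest than the measured one, because that measurement rests on one pair alone, compound 1 to compound 3 with a 7.6-fold higher number from compound 1 to compound 3 (0.88 log units; beyond the scatter), and on a different core. Compound 4 is therefore expected to reach about 6500 nM, most plausibly between 2500 nM and 18000 nM.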

Compound 4, maximal plasma concentration in the Canis familiaris assay: 2290 nM
Compound 4: the middle estimate sits 2.8-fold (0.45 log units) above what was measured; measured number outside the range, below it.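

In the Canis familiaris assay, putting hydrogen in place of butyl on the core of compound 2 brought a 1.2-fold higher number from compound 2 to compound 4 (0.07 log units; within the scatter). The size of this step did not carry over from one core to the other, so the earlier step is a poor guide here: the same change on two cores in the Canis familiaris assay, a 7.6-fold higher number (0.88 log units; beyond the scatter) from compound 1 to compound 3 and a 1.2-fold higher number (0.07 log units; within the scatter) from compound 2 to compound 4, 6.4-fold (0.81 log units) apart, beyond the scatter of two such steps

Two pairs cannot explain that gap. In a physicochemical assay for lipophilicity (a lower number here means a more polar compound, a higher number a more lipophilic compound), compound 2 gives 3.3, and compound 4 gives 1.11. On the core of compound 2 a clear fall in lipophilicity came without a step beyond the scatter in circulating compound: the measured partition coefficient of compound 2, 3.3, and of compound 4, 1.11, a number 2.19 log units lower (beyond the scatter)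

The compounds shown leave open how a smaller chain, such as methyl or ethyl, on the same saturated ring carbon would behave on each core. They also leave open which of the two steps a third core would resemble.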